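This account rests on a few compounds, and the source may have more. Where it says the series, first, only, none or still open, it means among the compounds named here.

Working notes on the series. In a functional assay on Ca-Ski cells (Homo sapiens) for cytotoxicity, read by sulforhodamine B assay, with a stated time of 48 h (a lower number here means a stronger inhibitor, a higher number a weaker inhibitor), compound 1 (`Cc1ccc2nc(NCCCCOc3cc(O)c4c(=O)cc(-c5ccccc5)oc4c3)sc2c1`) gives 15.5 ug/mL, compound 2 (`O=c1cc(-c2ccccc2)oc2cc(OCCCCNc3nc4ccc(Cl)cc4s3)cc(O)c12`) gives 12.4 ug/mL and compound 3 (`O=c1cc(-c2ccccc2)oc2cc(OCCCCNc3nc4ccc(F)cc4s3)cc(O)c12`) gives 13.4 ug/mL. Compound 2 therefore stands within the scatter of both neighbours, and the three cannot be ranked. The next change leads to compound 4 (`O=C(O)c1ccc2nc(NCCCCOc3cc(O)c4c(=O)cc(-c5ccccc5)oc4c3)sc2c1`): carboxy in place of chloro on an aromatic carbon, or 6-chloro-1,3-benzothiazol-2-yl to 6-carboxy-1,3-benzothiazol-2-yl. The closest evidence is the set of swaps at this same place: a 1.3-fold lower number from compound 1 to compound 2 (0.10 log units; within the scatter), a 1.2-fold lower number from compound 1 to compound 3 (0.06 log units; within the scatter) and a 1.1-fold higher number from compound 2 to compound 3 (0.03 log units; within the scatter). All three lie within the scatter, so this site has so far shown no measurable response in this assay. However, none of the measured compounds carries a carboxy group, so those steps only loosely cover this change. No clear shift is expected, with a slight allowance towards a higher number. The expected result is a 1.3-fold higher number from compound 2 to compound 4 (0.11 log units; within the scatter), which would not exceed the scatter. For compound 4 the estimate is 16 ug/mL, with an expected range of 7 ug/mL to 38 ug/mL.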

Compound 4, half-maximal inhibitory concentration: 12.1 ug/mL
Compound 4: middle estimate off by 1.3-fold (0.12 log units), on the high side, within the range that was stated.
By their numbers in this assay, from the lowest: compounds 4, 2, 3 and 1 (each within the scatter of the next).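

Replacing chloro with carboxy at this position of the 6-carboxy-1,3-benzothiazol-2-yl group adds heavy atoms, a hydrogen-bond donor and a hydrogen-bond acceptor, yet in this assay the number does not move beyond the scatter (a 1.0-fold lower number from compound 2 to compound 4 (0.01 log units; within the scatter)). The other two steps to compound 4 also stay within the scatter (a 1.1-fold lower number from compound 3 to compound 4 (0.04 log units; within the scatter); a 1.3-fold lower number from compound 1 to compound 4 (0.11 log units; within the scatter)), so the four compounds still cannot be ranked, and the flat response at this site now extends from methyl, chloro and fluoro to carboxy. No measurement at hand accounts for this flat response.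

The compounds shown leave open whether an amine or an amide on this same carbon would shift the number beyond the scatter. They also leave open whether a longer chain would do so where this position has not.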